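Methyl on the sulfonyl phenyl across two cores

The source may report more compounds than this note shows. Statements on the series, on what has been measured and on what is new or still open speak of the compounds shown alone.

The series contains four sulfonylurea-type compounds on two cores, read in a functional assay on MCF7 cells (Homo sapiens) for antiproliferative activity, read by MTT assay, with a stated time of 24 h, tested at 10 uM; a lower number here means less inhibition, a higher number more inhibition at the concentration tested (going by the name of the read-out). Compound 1 `O=C(NS(=O)(=O)c1ccccc1)n1ccc2cc(Br)cnc21` gives 16.8%. Compound 2 `Cc1ccc(S(=O)(=O)NC(=O)n2ccc3cc(Br)cnc32)cc1` gives 28%. The change from compound 1 to compound 2 is methyl in place of hydrogen on an aromatic carbon and it gave a number 11.2 percentage points higher from compound 1 to compound 2 (beyond the scatter).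

Compound 3 `CN(C)c1ccnc2c1ccn2C(=O)NS(=O)(=O)c1ccccc1` carries a different core; how the core of compound 3 differs from the core of compound 1 is not broken down here. In this assay compound 3 gives 26.9%, which lies close to compound 2 and apart from compound 1.

Compound 4 `Cc1ccc(S(=O)(=O)NC(=O)n2ccc3c(N(C)C)ccnc32)cc1` is not yet measured. It differs from compound 3 by methyl in place of hydrogen on an aromatic carbon, which is the same change as from compound 1 to compound 2: the group enters at the same kind of place on the sulfonyl phenyl, and nothing around that place differs between the two pairs.

The expectation for compound 4 rests on one earlier step only, and on a different core, so the size of the step is taken as uncertain but of the same direction. Among the compounds with values here, from compound 3 to compound 4 the step is estimated as a number 8.1 percentage points higher from compound 3 to compound 4 (within the scatter), somewhat smaller than the single earlier step because the earlier step from compound 1 to compound 2 gave a number 11.2 percentage points higher from compound 1 to compound 2 (beyond the scatter) on a different core, and its carry-over to the core of compound 3 is uncertain. Compound 4 is therefore estimated at 35%, expected to fall between 22% and 48%.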

Compound 4, a percentage reported as inhibition, at one concentration (the size of the read-out at that concentration, not a potency): 5.6%
Compound 4: middle estimate off by 29.4 percentage points, on the high side; measured number outside the range, below it.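

On the second core, the change from phenyl to 4-methylphenyl gives a number 21.3 percentage points lower from compound 3 to compound 4 (beyond the scatter) in this assay, so the gain seen on the core of compound 1 does not carry over to the core of compound 3, and the sign of the step depends on the core in this series. Set side by side, the two steps differ clearly, and a step taken from one of these cores is not a usable guide to the other: the same change on two cores in this assay, a number 11.2 percentage points higher (beyond the scatter) from compound 1 to compound 2 and a number 21.3 percentage points lower (beyond the scatter) from compound 3 to compound 4, 32.5 percentage points apart, beyond the scatter of two such steps This does not show which feature of the two cores goes with the reversal, nor that the reversal would hold on any further core, as it rests on one pair of compounds per core, each read at a single concentration and a single stated time in one cell line.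

Open, going by these compounds, is whether an ethyl group, a methoxy group or a chlorine atom in place of the methyl would also take opposite courses on the two cores. Also open, on these data alone, is whether the bromine or the dimethylamino group is the part of the cores that decides the direction of the step, or whether other differences between the cores do.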